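From 3-fluorobenzyl to 2,4-difluorobenzyl

A few compounds are considered here, and "the series" means these few. Any claim that something is new, unique, unknown or untested is made for them only; others in the source may bear on it.

Compound 1 `CC(C)(C)c1cc(/C=C/C(=O)NCCC2CCN(Cc3ccccc3)CC2)cc(C(C)(C)C)c1O`: 81700 nM
Compound 2 `CC(C)(C)c1cc(/C=C/C(=O)NCCC2CCN(Cc3cccc(F)c3)CC2)cc(C(C)(C)C)c1O`: 55200 nM

Within the data shown here, both compounds were tested in a functional assay, read by spectrophotometry, with a stated time of 30 min (a higher number here means a weaker inhibitor, a lower number a stronger inhibitor), and only two values are available so far. In this assay compound 2 gives 55200 nM, which cannot be told apart from compound 1 at 81700 nM. Compound 2 therefore stands level with compound 1 rather than ahead of it.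

Compound 3 `CC(C)(C)c1cc(/C=C/C(=O)NCCC2CCN(Cc3ccc(F)cc3F)CC2)cc(C(C)(C)C)c1O` differs from compound 2 in one place: 2,4-difluorophenyl in place of 3-fluorophenyl on a saturated chain carbon bound to an amine nitrogen in a ring. In words, 2,4-difluorophenyl stands in place of 3-fluorophenyl on a saturated chain carbon bound to an amine nitrogen in a ring. Among the measured compounds shown here, only one measured step bears on this change, the fluoro in place of hydrogen on an aromatic carbon that links the two tested compounds: a 1.5-fold lower number from compound 1 to compound 2 (0.17 log units; within the scatter). For the measured compounds named here, no tested compound carries 2,4-difluorophenyl, so this evidence is thin. It gives no reason to expect a shift beyond the scatter in either direction in this assay. The expected change is a 1.1-fold lower number from compound 2 to compound 3 (0.03 log units; within the scatter). For compound 3 the estimated value is 52000 nM, with an expected range of 23000 nM to 115000 nM.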

Compound 3, half-maximal inhibitory concentration: 62400 nM
Estimate against measurement, compound 3: 1.2-fold (0.08 log units) below, and the stated range covers the measured number.
By their numbers in this assay, from the lowest: compounds 2, 3 and 1 (each within the scatter of the next).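

In this assay, replacing 3-fluorophenyl with 2,4-difluorophenyl on a saturated chain carbon bound to an amine nitrogen in a ring gives a 1.1-fold higher number from compound 2 to compound 3 (0.05 log units; within the scatter), and replacing the plain phenyl with the same group gives a 1.3-fold lower number from compound 1 to compound 3 (0.12 log units; within the scatter), so neither comparison separates the compounds. Among these compounds, the earlier compounds offered only a single fluoro step, whereas this place has now carried phenyl, 3-fluorophenyl and 2,4-difluorophenyl, and all three compounds remain within the scatter of one another. Going from one fluorine to two on this ring therefore leaves the reading in this assay unresolved from that of the unsubstituted compound, and nothing at hand offers any explanation of this result.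

As far as these compounds go, all three compounds carry only hydrogen or fluorine on this ring, so it remains open whether a larger substituent such as methoxy or trifluoromethyl, or a hydroxyl group, would move the number beyond the scatter. From the compounds shown here alone, it is equally open whether replacing the phenyl ring itself with a pyridine, or changing the shared core elsewhere, for example with a longer chain at the amide, would have a larger effect than any change seen here.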